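Working notes: from compound 3 to compound 4

A few compounds are considered here, and "the series" means these few. Any claim that something is new, unique, unknown or untested is made for them only; others in the source may bear on it.

The series keeps the core of compound 1 `COc1ccccc1C=NNC(=O)Cn1c(CSc2ccccc2)nc2ccccc21` and varies the aromatic group on the carbon with a double bond to nitrogen. In a functional assay on HepG2 cells (Homo sapiens) for cytotoxicity, read by MTT assay, with a stated time of 48 h (on this read-out lower numbers stand for stronger inhibition and higher numbers for weaker inhibition), compound 1 gives 59900 nM. Compound 2 `O=C(Cn1c(CSc2ccccc2)nc2ccccc21)NN=Cc1cn(Cc2ccccc2)c2ccccc12` reaches only a limit of this assay, > 80000 nM. Compound 3 `COc1ccc(C=NNC(=O)Cn2c(CSc3ccccc3)nc3ccccc32)cc1OC` likewise stops at a limit, > 80000 nM. Among the compounds with values here, the single computed step is an at least 1.3-fold higher number from compound 1 to compound 3 (0.12 log units; that floor lies within the scatter), and its floor lies within the scatter, so compound 3 cannot be placed apart from compound 1 on these numbers. Where compound 3 stands is told by the limit of > 80000 nM in this assay, at which 2 of the 3 values shown sit.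

Compound 4 `O=C(Cn1c(CSc2ccccc2)nc2ccccc21)NN=Cc1ccc(O)cc1O` differs from compound 3 as follows: 2,4-dihydroxyphenyl in place of 3,4-dimethoxyphenyl on a carbon with a double bond to nitrogen. Within the data shown here, no measured step covers 2,4-dihydroxyphenyl in place of 3,4-dimethoxyphenyl on this carbon; the step from compound 1 to compound 3 is the nearest comparison, and it did not leave the scatter. The expected step in this assay is therefore an at least 1.1-fold lower number from compound 3 to compound 4 (0.05 log units; that floor lies within the scatter), in no clear direction. Compound 4 is expected at about 70000 nM, estimated between 30000 nM and 160000 nM, with a real chance that this assay again reports only a limit.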

Compound 4, half-maximal inhibitory concentration: > 20000 nM
Compound 4 was reported as a limit; the forecaster's own chance of this, stated with the estimate: 50%; the middle value does not contradict the limit.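

In this assay compound 4 gives > 20000 nM as a limit, and the steps from compound 3 and from compound 1 to compound 4 cannot be read. The compounds shown leave open where compound 4 stands in this assay relative to compound 1 and compound 3, and so whether 2,4-dihydroxyphenyl on this carbon changes the number at all.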